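This account rests on a few compounds, and the source may have more. Where it says the series, first, only, none or still open, it means among the compounds named here.

Measured in a functional assay on SK-MEL-28 cells (Homo sapiens) for inhibition, read by MTT assay, with a stated time of 72 h; on this read-out lower numbers stand for stronger inhibition of growth and higher numbers for weaker inhibition of growth:
- compound 1 `CC1(C)CCC[C@]2(C)[C@@H](C=O)C(C=O)=CC[C@@H]12`: 65000 nM
- compound 2 `CC(C)(C)OC(=O)/C=C/C1=CC[C@H]2C(C)(C)CCC[C@]2(C)[C@H]1C=O`: 41000 nM
- compound 3 `COC(=O)/C=C/C=C/C1=CC[C@H]2C(C)(C)CCC[C@]2(C)[C@H]1C=O`: 25000 nM

Compound 3 has the lowest number of the three. Its gap to compound 2 lies within the scatter, while its gap to compound 1 lies beyond it. Compound 4 `CC1(C)CCC[C@]2(C)[C@@H](C=O)C(/C=C/C#N)=CC[C@@H]12` has cyano in place of 2-(methoxycarbonyl)ethenyl on a double-bonded chain carbon bound to a double-bonded chain carbon. Among the measured compounds shown here, the one measured exchange at this place, a 1.6-fold lower number from compound 2 to compound 3 (0.21 log units; within the scatter), was small. For the measured compounds named here, no cyano compound has been measured yet, so this guide is thin, and no shift beyond the scatter is expected in this assay. The expected change is a 1.2-fold higher number from compound 3 to compound 4 (0.08 log units; within the scatter). For compound 4 the estimate is 30000 nM, with an expected range of 12000 nM to 70000 nM.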

Compound 4, concentration for 50% growth inhibition: 42000 nM
Beside the measured number, compound 4's estimate is 1.4-fold (0.15 log units) below it, and the stated range covers the measured number.
By their numbers in this assay, from the lowest: compounds 3, 2, 4 and 1 (each within the scatter of the next, the first and the last beyond it).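

Cyano at this place, a smaller group than 2-(methoxycarbonyl)ethenyl, gives no shift beyond the scatter (a 1.7-fold higher number from compound 3 to compound 4 (0.23 log units; within the scatter)). The same holds for cyano in place of tert-butoxycarbonyl (a 1.0-fold higher number from compound 2 to compound 4 (0.01 log units; within the scatter)) and for 2-cyanoethenyl in place of formyl on a double-bonded ring carbon (a 1.5-fold lower number from compound 1 to compound 4 (0.19 log units; within the scatter)). Compound 4 therefore stays within the scatter of compounds 1, 2 and 3, even though the groups differ in size.

No supporting data explain these small steps. Going by these compounds, whether an amine or a carboxylic acid at this place would shift the number beyond the scatter remains open.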